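Carboxy replacing ethyl on the fused aromatic ring

A few compounds are considered here, and "the series" means these few. Any claim that something is new, unique, unknown or untested is made for them only; others in the source may bear on it.

Compound 3 `CCc1ccc2[nH]c(CC(CC(=O)O)c3ccc(Cl)cc3)nc2c1` carries an ethyl on the fused aromatic ring of the shared core. In an assay on isolated protein for inhibition of protein kinase C zeta type (Homo sapiens), read by 33P incorporation, tested at 200 uM (on this read-out lower numbers stand for a weaker effect and higher numbers for a stronger effect at the one concentration tested), compound 3 gives 0%. This stands level with compound 2 `Cc1ccc2[nH]c(CC(CC(=O)O)c3ccc(Cl)cc3)nc2c1`, which in this assay gives 0%; together they are the lowest of the three numbers, and the pair shows no change at the digits printed from compound 2 to compound 3 (within the scatter). Furthest away is compound 1 `O=C(O)CC(Cc1nc2cc(Br)ccc2[nH]1)c1ccc(Cl)cc1`, which in this assay gives 80%, the bromo analogue, with a number 80 percentage points lower from compound 1 to compound 3 (beyond the scatter) and likewise a number 80 percentage points lower from compound 1 to compound 2 (beyond the scatter).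

Compound 4 `O=C(O)CC(Cc1nc2cc(C(=O)O)ccc2[nH]1)c1ccc(Cl)cc1` differs from compound 3 by carboxy in place of ethyl on an aromatic carbon. The measured steps that bear on this position are the two large losses on going from bromo to methyl and from bromo to ethyl, and the flat step between the two alkyls. None of them places a carboxy at this position, so the direction from an alkyl to a carboxy is not fixed by the data; what the steps do show is that a single change at this position can move the number across most of the read-out. A modest upward step, a number 20 percentage points higher from compound 3 to compound 4 (beyond the scatter), is expected, with wide uncertainty. For compound 4 the estimate in this assay is 20%, expected to fall between 0% and 70%.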

Compound 4, a percentage reported as inhibition, at one concentration (the size of the read-out at that concentration, not a potency): 0%
Beside the measured number, compound 4's estimate is 20 percentage points above it; the range from low to high includes it.
By their numbers in this assay, from the lowest: compounds 2, 3 and 4 (each within the scatter of the next); then compound 1.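

In this assay, the step to carboxy is flat against both alkyls, with no change at the digits printed from compound 3 to compound 4 (within the scatter) and no change at the digits printed from compound 2 to compound 4 (within the scatter), so a group that brings in oxygen, a double bond outside the aromatic rings and a hydrogen-bond donor and acceptor reads the same here as ethyl and methyl. The loss from the bromo analogue now extends to a third replacement, with a number 80 percentage points lower from compound 1 to compound 4 (beyond the scatter), so in these four compounds only compound 1 stands apart, while compounds 2, 3 and 4 share the same printed value despite their different groups. Nothing on hand explains why bromo alone gives a number well off the others at this position.

On these data alone, whether chloro or iodo at this position would read like bromo, or an amine or a methoxy would read like the alkyls and carboxy, remains open. Also open, as far as these compounds go, is how compound 1 behaves at lower concentrations, and whether bromo keeps its effect when the carboxylic acid on the side chain or the chloro on the phenyl ring is replaced.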